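Sulfur substituent step from compound 3 to compound 4

The compounds below may be only part of what the source reports. "The series", "measured", "known", "first", "only" and "open" are said of these compounds alone.

Three compounds sharing one core have numbers in a functional assay on HCT-116 cells (Homo sapiens) for inhibition, read by CCK-8 assay, with a stated time of 72 h, tested at 8 uM; a higher number here means more inhibition of growth at the concentration tested, a lower number less inhibition of growth. Compound 1 `COc1ccc(SCc2ccc(/C=C/C(=O)Nc3ccccc3N)cc2)cc1OC` gives 49.5%, compound 2 `Nc1ccccc1NC(=O)/C=C/c1ccc(CSc2cccc(F)c2)cc1` gives 3.22% and compound 3 `Nc1ccccc1NC(=O)/C=C/c1ccc(CSc2ccc(C(F)(F)F)cn2)cc1` gives 14.9%. Compound 3 therefore stands second highest of the three, above compound 2 and well under compound 1, with both gaps beyond the scatter.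

The next change leads to compound 4 `Cc1ccc(SCc2ccc(/C=C/C(=O)Nc3ccccc3N)cc2)cc1`, with 4-methylphenyl in place of 5-(trifluoromethyl)pyridin-2-yl on a sulfur.

All three measured steps change the group at this same sulfur. Two are large, a number 46.3 percentage points lower from compound 1 to compound 2 (beyond the scatter) and a number 34.6 percentage points lower from compound 1 to compound 3 (beyond the scatter), and one is modest, a number 11.7 percentage points higher from compound 2 to compound 3 (beyond the scatter). All lie beyond the scatter, so a change here can move the read-out a long way. Compound 1 at 49.5% and compound 2 at 3.22% both carry a ring of carbon only, yet they stand at the two ends of the range, so ring type alone sets no direction.

A position inside that range is expected, which points to a modest rise with wide uncertainty. The expected size is a number 12.1 percentage points higher from compound 3 to compound 4 (beyond the scatter). For compound 4 the estimate is 27%, with an expected range of 6% to 50%.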

Compound 4, percent growth inhibition at one concentration: 4.93%
The estimate for compound 4 lay 22.1 percentage points above the measured number, outside the stated range (below it).
By their numbers in this assay, from the lowest: compounds 2, 4 and 3 (each within the scatter of the next, the first and the last beyond it); then compound 1.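

In this assay the 4-methylphenyl group on the sulfur gives a number 10 percentage points lower from compound 3 to compound 4 (within the scatter) and a number 1.7 percentage points higher from compound 2 to compound 4 (within the scatter) and so cannot be separated from either 5-(trifluoromethyl)pyridin-2-yl or 3-fluorophenyl, although compound 2 and compound 3 differ from each other beyond the scatter. The remaining step is a number 44.6 percentage points lower from compound 1 to compound 4 (beyond the scatter) and shows that a ring of carbon only is not enough for the higher number: compound 2 and compound 4 both carry such a ring, and among the four compounds only compound 1, with 3,4-dimethoxyphenyl, stands clear of the others. Nothing shown gives a reason for this separation.

As far as these compounds go, whether both methoxy groups are needed stays open, as a phenyl ring carrying a single methoxy group, or an ethoxy group in place of methoxy, would be the direct test at this sulfur. From the compounds shown here alone, each number also comes from one concentration, so how these groups would compare across a full concentration range remains unknown.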